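The source may report more compounds than this note shows. Statements on the series, on what has been measured and on what is new or still open speak of the compounds shown alone.

Measured compounds:
Compound 1 `N#CC1=C(NCN2CCCC2)N(c2ccccc2)C(=O)N2CCCCC(N3CCCC3)C12` gives 35.3% in a functional assay on the whole organism (strain albino) for inhibition, with Rattus norvegicus as the target, read by paw edema, with stated times of 1 h and 3 h, at a dose of 20 mmol/kg by the intraperitoneal route; on this read-out lower numbers stand for a weaker effect and higher numbers for a stronger effect at the one dose given.
Compound 2 `CCOC(=O)C(=O)NC1=C(C#N)C2C(N3CCCC3)CCCCN2C(=O)N1c1ccccc1` gives 91.5%.
Compound 3 `N#CC1=C(N)N(c2ccccc2)C(=O)N2CCCCC(N3CCCC3)C12` gives 90.1%.

Compound 3 stands second highest of the three numbers in this assay; its value and that of compound 2 lie within the scatter of each other, while compound 1 sits far lower. Compound 4 `N#CC1=C(NCC(=O)N2CCCCC2)N(c2ccccc2)C(=O)N2CCCCC(N3CCCC3)C12` differs from compound 3 in one place: ((piperidin-1-yl)carbonyl)methyl in place of hydrogen on an amine nitrogen. Within the data shown here, two measured steps touch this same amine nitrogen. Going a number 54.8 percentage points higher from compound 1 to compound 3 (beyond the scatter), so removing the (pyrrolidin-1-yl)methyl group raised inhibition greatly; going a number 1.4 percentage points lower from compound 2 to compound 3 (within the scatter), so removing the (ethoxycarbonyl)carbonyl group changed nothing beyond the scatter. The entering group in compound 4 contains a piperidin-1-yl part, recalling the pyrrolidin-1-yl of compound 1, and a carbonyl, recalling compound 2, so the two precedents point in different directions. Because a number 54.8 percentage points higher from compound 1 to compound 3 (beyond the scatter) was large, some loss from compound 3 is plausible, yet because a number 1.4 percentage points lower from compound 2 to compound 3 (within the scatter) was flat, the value could also stay near that of compound 3. The expected step of a number 25.1 percentage points lower from compound 3 to compound 4 (beyond the scatter) is therefore a moderate drop, with wide uncertainty. Compound 4 is estimated at 65%, in a range from 35% to 92%.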

Compound 4, a percentage reported as inhibition, in the whole organism at one dose (the size of the read-out at that dose, not a potency): 53.5%
The estimate for compound 4 lay 11.5 percentage points above the measured number, and the stated range covers the measured number.
By their numbers in this assay, from the lowest: compound 1; then compound 4; then compounds 3 and 2 (each within the scatter of the next).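

In this assay the ((piperidin-1-yl)carbonyl)methyl group on this amine nitrogen is not carried without loss: there is a number 36.6 percentage points lower from compound 3 to compound 4 (beyond the scatter) and also a number 38 percentage points lower from compound 2 to compound 4 (beyond the scatter) in a comparison with the (ethoxycarbonyl)carbonyl group. A carbonyl somewhere in the entering group is therefore not enough to hold the high value, so this nitrogen separates groups that both contain one. The swap of pyrrolidin-1-yl for (piperidin-1-yl)carbonyl on the saturated chain carbon bound to the amine nitrogen gives a number 18.2 percentage points higher from compound 1 to compound 4 (beyond the scatter) and so recovers only part of what compound 1 lacks, which shows that the far end of such a chain also matters for the paw edema result at this single dose.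

Still open, from the compounds shown here alone, is how a plain ethyl group on this nitrogen would behave, as well as a longer chain before the carbonyl, or a carboxylic acid or a morpholine amide in place of the (piperidin-1-yl)carbonyl part. Nothing in the data shown explains why any of these steps takes the size it does.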